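Ester Becomes Amide on the Indole Side Chain

This account rests on a few compounds, and the source may have more. Where it says the series, first, only, none or still open, it means among the compounds named here.

Measured so far:
compound 1, `CC(C)(C)OC(=O)/C(C#N)=C/c1cc2ccccc2[nH]1`, in a functional assay on the whole organism (strain CD1) for inhibition, with Mus musculus as the target, with stated times of 15 min and 20 min, at a dose of 10 mg/kg by the subcutaneous route (a lower number here means less inhibition, a higher number more inhibition at the dose given (going by the name of the read-out)), gives 51.3%
compound 2, `CC(C)CCOC(=O)/C(C#N)=C/c1cc2ccccc2[nH]1`, in this assay gives 46.6%

Within the data shown here, compound 2 has the lowest of the two numbers, but the only measured step, a number 4.7 percentage points lower from compound 1 to compound 2 (within the scatter), lies within the scatter, so the two compounds cannot be set in order. Compound 3, `CCNC(=O)/C(C#N)=C/c1cc2ccccc2[nH]1`, differs from compound 2 in a single place: ethylamino in place of isopentyloxy on a carbonyl carbon. Among the measured compounds shown here, no measured step touches the carbonyl side in this way; the one known step swapped one alkyl chain for another on the oxygen, and it stayed within the scatter. There is thus no ground for expecting a shift in either direction in this assay beyond the scatter, only a wider uncertainty. Compound 3 is therefore estimated at 45%, within 22% to 68%, which means an expected step of a number 1.6 percentage points lower from compound 2 to compound 3 (within the scatter).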

Compound 3, a percentage reported as inhibition, in the whole organism at one dose (the size of the read-out at that dose, not a potency): 45%
Compound 3: middle estimate and measured number agree at the digits printed; the range from low to high includes it.
By their numbers in this assay, from the lowest: compounds 3, 2 and 1 (each within the scatter of the next).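

In this assay, ethylamino on a carbonyl carbon gives a number 1.6 percentage points lower from compound 2 to compound 3 (within the scatter) when it replaces isopentyloxy, and a number 6.3 percentage points lower from compound 1 to compound 3 (within the scatter) when it replaces tert-butoxy. The earlier compounds differed only in the chain on an ester oxygen, whereas these steps show that among these three compounds, an ester can become an amide, with 3 heavy atoms in the entering group against 6 in isopentyloxy, without a step beyond the scatter. No measurement at hand bears on how the ester and the amide compare in this read-out.

As far as these compounds go, whether a longer chain on the amide nitrogen, an unsubstituted amide or a carboxylic acid at this carbonyl carbon would keep the number within the scatter remains open. The read-out comes from a single dose, so how these compounds compare at other doses is open too.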